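The compounds below may be only part of what the source reports. "The series", "measured", "known", "first", "only" and "open" are said of these compounds alone.

For the measured compounds named here, compound 1, with the structure `CS(=O)(=O)Nc1ccc2c(c1)S(=O)(=O)N=C(C1=C(O)C3CCCC3N(Cc3ccc(F)cn3)C1=O)N2`, is one of three compounds measured in an ADME assay on Huh-7 cells (Homo sapiens) for cytotoxicity, with a stated time of 72 h; a lower number here means that less compound is tolerated, a higher number that more compound is tolerated. For compound 1 the result is a limit of the assay, > 33000 nM, and not a number. Compound 3 has the structure `CC(C)(C)CCN1C(=O)C(C2=NS(=O)(=O)c3cc(NS(C)(=O)=O)ccc3N2)=C(O)C2CCCCC21`. For compound 3 the outcome is likewise a limit, > 33000 nM. Compound 2 has the structure `Cc1cc(CN2C(=O)C(C3=NS(=O)(=O)c4cc(NS(C)(=O)=O)ccc4N3)=C(O)[C@H]3CCC[C@H]32)ccc1F`. For compound 2 the outcome is a limit as well, > 1000 nM. So compound 1 stands at the limit of > 33000 nM in this assay, at which 2 of the 3 values shown sit, shared with compound 3, while the limit of > 1000 nM in this assay, at which 1 of the 3 values shown sits, is where the remaining value sits; no two of these compounds give numbers that could be compared as a step, so no step is known.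

Compound 4 is `CC(C)CCN1C(=O)C(C2=NS(=O)(=O)c3cc(NS(C)(=O)=O)ccc3N2)=C(O)C2CCCC21`. It differs from compound 1 in one place: isobutyl in place of 5-fluoropyridin-2-yl on a saturated chain carbon bound to an amide-type nitrogen in a ring. Compound 3 also carries a saturated chain in that place, and in this assay compound 3 gives only the limit > 33000 nM. Going by the values given here, no step between measured compounds exists to guide the size of the change, so compound 4 is expected to stay at the limit, with a step that the limit leaves unreadable from compound 1 to compound 4 that amounts to no change beyond the scatter. The estimate for compound 4 is 40000 nM, expected to lie between 20000 nM and 100000 nM.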

Compound 4, half-maximal cytotoxic concentration: > 1000 nM
Compound 4: no number, only a limit; the forecaster's own chance of this, stated with the estimate: 85%; the middle value is on the limit's open side.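

Compound 1 and compound 4 both give only limits of the assay in this assay, not numbers, so the step between them cannot be read. The compounds shown leave open whether isobutyl in place of 5-fluoropyridin-2-yl changes how much compound the cells tolerate, and by how much; all four give only limits.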